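Swapping the Aroyl Group on a Methoxy-Bearing Core

A few compounds are considered here, and "the series" means these few. Any claim that something is new, unique, unknown or untested is made for them only; others in the source may bear on it.

Of the compounds shown here, three sharing one core have been tested, and a fourth awaits its number. Compound 1 `COc1ccc(C(=O)n2c(-c3cn(C)c4ccccc34)nc3ccccc32)cc1OC` carries a 3,4-dimethoxyphenyl group on its carbonyl carbon; in a functional assay on HepG2 cells (Homo sapiens) for inhibition, read by MTT assay, with a stated time of 24 h (on this read-out higher numbers stand for weaker inhibition of growth and lower numbers for stronger inhibition of growth), compound 1 gives 8400 nM. Compound 2 `Cn1cc(-c2nc3ccccc3n2C(=O)c2ccccc2Br)c2ccccc21` differs from compound 1 only by 2-bromophenyl in place of 3,4-dimethoxyphenyl on a carbonyl carbon, and in this assay compound 2 gives 68200 nM. That single exchange brought an 8.1-fold higher number from compound 1 to compound 2 (0.91 log units; beyond the scatter). Compound 3 `COc1ccc2c(c1)c(-c1nc3ccccc3n1C(=O)c1ccc(OC)c(OC)c1)cn2C` keeps the 3,4-dimethoxyphenyl group but its core differs from that of compound 1 by methoxy in place of hydrogen on an aromatic carbon; in this assay compound 3 gives 5100 nM, a difference of a 1.6-fold lower number from compound 1 to compound 3 (0.22 log units; within the scatter).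

Compound 4 `COc1ccc2c(c1)c(-c1nc3ccccc3n1C(=O)c1ccccc1Br)cn2C` is not yet measured. It stands to compound 3 as compound 2 stands to compound 1: the change is 2-bromophenyl in place of 3,4-dimethoxyphenyl on a carbonyl carbon, at the same place, so it is the same change seen once before. Because the earlier instance gave an 8.1-fold higher number from compound 1 to compound 2 (0.91 log units; beyond the scatter), the expected step in this assay from compound 3 to compound 4 is of a similar size, a 7.8-fold higher number from compound 3 to compound 4 (0.89 log units; beyond the scatter). Among the compounds with values here, this rests on a single prior pair, so the expectation is loose, and the methoxy-bearing core of compound 3 has not yet been seen with a 2-bromophenyl group. Compound 4 is therefore estimated to give about 40000 nM in this assay, with a plausible range from 15000 nM to 110000 nM.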

Compound 4, concentration for 50% growth inhibition: 54200 nM
Beside the measured number, compound 4's estimate is 1.4-fold (0.13 log units) below it; the range from low to high includes it.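

In this assay, putting 2-bromophenyl in place of 3,4-dimethoxyphenyl on the carbonyl carbon gave a step beyond the scatter on the methoxy-bearing core too (an 11-fold higher number from compound 3 to compound 4 (1.03 log units; beyond the scatter)), and the change carried over from one core to the other with little difference in size: the same change on two cores in this assay, an 8.1-fold higher number (0.91 log units; beyond the scatter) from compound 1 to compound 2 and an 11-fold higher number (1.03 log units; beyond the scatter) from compound 3 to compound 4, 1.3-fold (0.12 log units) apart, within the scatter of two such steps. Read the other way, methoxy in place of hydrogen on an aromatic carbon stays within the scatter with the 2-bromophenyl group (a 1.3-fold lower number from compound 2 to compound 4 (0.10 log units; within the scatter)), just as it did with the 3,4-dimethoxyphenyl group, so the two changes behave as independent of each other in these four compounds: the same change on two cores in this assay, a 1.6-fold lower number (0.22 log units; within the scatter) from compound 1 to compound 3 and a 1.3-fold lower number (0.10 log units; within the scatter) from compound 2 to compound 4, 1.3-fold (0.12 log units) apart, within the scatter of two such steps. Within the data shown here, this shows that the exchange transfers between two cores differing by a single methoxy group, but it rests on only two pairs and does not show that it would transfer to a more different core, nor does it explain why the step occurs.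

The exchange removes two methoxy groups and adds a bromine in one move, so it remains open which of these accounts for the step, and a plain phenyl group on the carbonyl carbon would help separate them. As far as these compounds go, it also remains open how an amine or a carboxylic acid on that ring would behave in this assay.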